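This account rests on a few compounds, and the source may have more. Where it says the series, first, only, none or still open, it means among the compounds named here.

Compound 1 `CCN(CC)CCCNc1nc(-c2ccc(NC(=O)Nc3ccc(Cl)cc3)cc2)nc2c(Cl)c(Cl)sc12` and compound 2 `CCN(CC)CCNc1nc(-c2ccc(NC(=O)Nc3ccc(Cl)cc3)cc2)nc2c(Cl)c(Cl)sc12` share a core and differ only in the chain that carries the diethylamino group. In a functional assay on MKN-45 cells (Homo sapiens) for cytotoxicity, read by MTT assay, with a stated time of 72 h (a lower number here means a stronger inhibitor, a higher number a weaker inhibitor), compound 1 gives 720 nM, and compound 2 gives 890 nM. Among the compounds with values here, the step of a 1.2-fold higher number from compound 1 to compound 2 (0.09 log units; within the scatter) is within the scatter, so the two values cannot be ranked against each other; compound 2 stands within the scatter of the only other compound measured.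

Compound 3 `CCN(CC)CCNc1nc(-c2ccc(NC(=O)Nc3ccc(C)cc3)cc2)nc2c(Cl)c(Cl)sc12` differs from compound 2 by methyl in place of chloro on an aromatic carbon. Within the data shown here, no measured step touches this part of the molecule: the single step between compound 1 and compound 2 concerns the chain on the other side of the core and says nothing about the aromatic carbon where the chloro sits. There is therefore no measured basis for a shift in this assay, and the expectation is a step of no more than the scatter, a 1.0-fold higher number from compound 2 to compound 3 (0.00 log units; within the scatter), in either direction. On that ground compound 3 is estimated at 900 nM, with a range from 400 nM to 2200 nM.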

Compound 3, half-maximal inhibitory concentration: 1450 nM
Compound 3: the middle estimate sits 1.6-fold (0.21 log units) below what was measured; the range from low to high includes it.
By their numbers in this assay, from the lowest: compounds 1, 2 and 3 (each within the scatter of the next).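

In this assay, the exchange of chloro for methyl on an aromatic carbon, para to a large group, gives a 1.6-fold higher number from compound 2 to compound 3 (0.21 log units; within the scatter), which places the 4-chlorophenyl and 4-methylphenyl forms within reach of each other and does not allow them to be ranked. Within the data shown here, this is the first measured step at this end of the molecule, whereas the earlier pair spoke only to the chain carrying the diethylamino group, so the position now has a reading of its own: between these two groups, the change of a single heavy atom does not separate the compounds beyond the usual spread of repeat measurements. No measurement at hand bears on what lies behind this result.

The compounds shown leave open whether another group at the same place, such as a methoxy group, a trifluoromethyl group or a bare hydrogen, would move the number beyond the scatter. They also leave open whether the methyl group would give a similar reading on the longer chain of compound 1, since the two changes are seen only one at a time.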